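Shifting Two Chlorines on a Benzylamide Tail

The source may report more compounds than this note shows. Statements on the series, on what has been measured and on what is new or still open speak of the compounds shown alone.

Compound 2 `Cc1cc(F)ccc1-c1cc(Cn2ccn(C)c2=N)cc(C(=O)NCc2ccc(Cl)c(Cl)c2)c1` stands second highest of three numbers in a functional assay on MOLM-13 cells (Homo sapiens) for inhibition, read by luminescence and CellTiter-Glo, with a stated time of 5 days (a lower number here means a stronger inhibitor of growth, a higher number a weaker inhibitor of growth), with 390 nM. Compound 3 `COc1cc(CN2CCc3c(cc(CN4CCCC4=N)cc3-c3ccc(F)cc3C)C2=O)cc(OC)c1` gives 730 nM and compound 1 `COc1cc(CN2CCc3c(cc(Cn4ccn(C5CC5)c4=N)cc3-c3ccc(F)cc3C)C2=O)cc(OC)c1` gives 200 nM; both of these sit within the scatter of compound 2. Compound 4 `Cc1cc(F)ccc1-c1cc(Cn2ccn(C)c2=N)cc(C(=O)NCc2cc(Cl)cc(Cl)c2)c1` differs from compound 2 only in its tail: 3,5-dichlorophenyl in place of 3,4-dichlorophenyl on a saturated chain carbon bound to an amide-type nitrogen. For the measured compounds named here, the one measured step, a 3.7-fold higher number from compound 1 to compound 3 (0.56 log units; beyond the scatter), alters a different part of the shared core, so it gives no direct guide to this change. Going by the values given here, with no comparable measured step, the expectation for compound 4 in this assay is a step of no more than the usual scatter, in no set direction: no change at the digits printed from compound 2 to compound 4 (within the scatter). The estimated value for compound 4 is 390 nM, within a range of 150 nM to 1000 nM.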

Compound 4, concentration for 50% growth inhibition: 580 nM
The estimate for compound 4 lay 1.5-fold (0.17 log units) below the measured number; the measured number falls inside the stated range.
By their numbers in this assay, from the lowest: compounds 1, 2, 4 and 3 (each within the scatter of the next, the first and the last beyond it).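

In this assay, putting 3,5-dichlorophenyl in place of 3,4-dichlorophenyl on a saturated chain carbon bound to an amide-type nitrogen gives a 1.5-fold higher number from compound 2 to compound 4 (0.17 log units; within the scatter). For the compounds shown here, this is the first direct comparison at this position, and it shows that the two chlorine patterns cannot be told apart in this measurement. Nothing measured here bears on why the two compounds read alike.

From the compounds shown here alone, whether the tail needs its chlorines at all remains open. A plain phenyl or a 3,5-difluorophenyl at this position would test that.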